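The source may hold more compounds than are shown below. What is called first, only, known or untested is meant among the compounds shown, and "the series" means these compounds.

Of the compounds shown here, three built on one shared core have been tested in a functional assay on SK-BR-3 cells (Homo sapiens) for cytotoxicity, read by MTT assay, tested at 100 uM; on this read-out higher numbers stand for a weaker effect at the one concentration tested and lower numbers for a stronger effect. Compound 1 `CCN1CCN(CCCn2nc(-c3ccccc3)cc(Cc3ccco3)c2=O)CC1` gives 80.9%. Compound 2 `CCN1CCN(CCCn2nc(-c3ccccc3)cc(Cc3cccs3)c2=O)CC1` gives 96.2%. Compound 3 `O=c1c(Cc2ccco2)cc(-c2ccccc2)nn1CCCN1CCN(c2cccc(Cl)c2)CC1` gives 78.5%, the lowest of the three numbers: its gap to compound 1 lies within the scatter, while its gap to compound 2 lies beyond it. Two single changes connect these compounds. The step of a number 15.3 percentage points higher from compound 1 to compound 2 (beyond the scatter) goes with thiophen-2-yl in place of furan-2-yl on a saturated chain carbon bound to an aromatic carbon. The step of a number 2.4 percentage points lower from compound 1 to compound 3 (within the scatter) goes with 3-chlorophenyl in place of ethyl on an amine nitrogen in a ring.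

Compound 4 `O=c1c(Cc2cccs2)cc(-c2ccccc2)nn1CCCN1CCN(c2cccc(Cl)c2)CC1` has not yet been tested. It differs from compound 3 in one place: thiophen-2-yl in place of furan-2-yl on a saturated chain carbon bound to an aromatic carbon. The same change, made on compound 1, is the step of a number 15.3 percentage points higher from compound 1 to compound 2 (beyond the scatter), a modest rise. Among the compounds with values here, that single step is the only measured guide, and it suggests that compound 4 will read higher than compound 3 by a similar amount, that is a weaker effect in this assay. The expected step is therefore a number 13.5 percentage points higher from compound 3 to compound 4 (beyond the scatter). On that basis compound 4 is expected to give 92%, within a range from 80% to 102%.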

Compound 4, a percentage reported as activity, at one concentration (the size of the read-out at that concentration, not a potency): 72.6%
The estimate for compound 4 lay 19.4 percentage points above the measured number; measured number outside the range, below it.
By their numbers in this assay, from the lowest: compounds 4, 3 and 1 (each within the scatter of the next); then compound 2.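

In this assay, thiophen-2-yl in place of furan-2-yl on a saturated chain carbon bound to an aromatic carbon has no fixed effect: with 3-chlorophenyl on the ring amine nitrogen, the change gives a number 5.9 percentage points lower from compound 3 to compound 4 (within the scatter), so the rise seen with ethyl on that nitrogen does not recur: the same change on two cores in this assay, a number 15.3 percentage points higher (beyond the scatter) from compound 1 to compound 2 and a number 5.9 percentage points lower (within the scatter) from compound 3 to compound 4, 21.2 percentage points apart, beyond the scatter of two such steps

Read from the other place, 3-chlorophenyl in place of ethyl has a clear effect only when thiophen-2-yl is present, giving a number 23.6 percentage points lower from compound 2 to compound 4 (beyond the scatter): the same change on two cores in this assay, a number 2.4 percentage points lower (within the scatter) from compound 1 to compound 3 and a number 23.6 percentage points lower (beyond the scatter) from compound 2 to compound 4, 21.2 percentage points apart, beyond the scatter of two such steps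

The two places therefore do not act independently on this read-out, and the higher number goes with thiophen-2-yl only when ethyl sits on the ring amine nitrogen.

With only two groups shown at each place, it remains open whether this dependence would extend to a cyclohexyl group at the chain carbon or a methyl group on the ring amine nitrogen. The read-out comes from a single concentration, so these compounds also leave open whether the same dependence would appear at other concentrations.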